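From compound 2 to compound 3: 4-carboxyphenyl enters

This account rests on a few compounds, and the source may have more. Where it says the series, first, only, none or still open, it means among the compounds named here.

In a functional assay (trachea) with Cavia porcellus as the target (a higher number here means a weaker inhibitor, a lower number a stronger inhibitor), compound 1 `O=c1c2ccccc2c(-c2cccnc2)nn1Cc1ccccc1` gives 2450 nM and compound 2 `O=c1c2ccccc2c(-c2cccnc2)nn1CCSc1ncccn1` gives 11000 nM, the higher number of the two and so the weaker inhibitor. The next structure is compound 3 `O=C(O)c1ccc(Cn2nc(-c3cccnc3)c3ccccc3c2=O)cc1`, with 4-carboxyphenyl in place of ((pyrimidin-2-yl)sulfanyl)methyl on a saturated chain carbon bound to an aromatic nitrogen.

Among the measured compounds shown here, only one measured step bears on this change: a 4.5-fold higher number from compound 1 to compound 2 (0.65 log units; beyond the scatter), modest and beyond the scatter, made at the same place. Compound 3 shares a phenyl ring at that place with compound 1, which gives 2450 nM, so part of that step is expected to be recovered. For the measured compounds named here, no measured compound carries a carboxy substituent, so its contribution is unknown and the range has to stay wide. The expected change is modest and towards a lower number: a 2.0-fold lower number from compound 2 to compound 3 (0.30 log units; within the scatter). The estimated value for compound 3 is 5500 nM, with an expected range of 1500 nM to 20000 nM.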

Compound 3, half-maximal inhibitory concentration: 17000 nM
Compound 3: the middle estimate sits 3.1-fold (0.49 log units) below what was measured, and the stated range covers the measured number.
By their numbers in this assay, from the lowest: compound 1; then compounds 2 and 3 (each within the scatter of the next).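

In this assay, among the compounds shown here, the single change of carboxy on the phenyl ring of compound 1 gives a 6.9-fold higher number from compound 1 to compound 3 (0.84 log units; beyond the scatter), so this position does not accept that substituent without a loss of inhibition, which the earlier pair could not show because it changed the whole group. The other step, a 1.5-fold higher number from compound 2 to compound 3 (0.19 log units; within the scatter), does not separate 4-carboxyphenyl from ((pyrimidin-2-yl)sulfanyl)methyl at this place on a saturated chain carbon bound to an aromatic nitrogen, so keeping a six-membered aromatic ring of carbon only is not enough to hold the number of compound 1 at 2450 nM. No measured evidence on the series accounts for either step.

As far as these compounds go, whether the loss belongs to the carboxylic acid itself stays open: a methyl ester, a primary amide or an amine in place of the carboxy would be needed to tell. From the compounds shown here alone, it also remains open whether a longer chain between the shared core and the 4-carboxyphenyl ring, or a simple methoxy substituent on the phenyl ring of compound 1, would move the number in this assay at all.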